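The compounds below may be only part of what the source reports. "The series", "measured", "known", "first", "only" and "open" are said of these compounds alone.

Compound 1 `Cc1cnc(NC(=O)c2cc(Oc3cnc(C(=O)N(C)C)cn3)c3cc(C)oc3c2)cn1` gives 22.3 10^-6 cm/s
Compound 2 `Cc1cnc(NC(=O)c2cc(Oc3cnc(C(=O)N(C)C)cn3)c3cc(C)nn3c2)cn1` gives 17 10^-6 cm/s
Compound 3 `Cc1cnc(NC(=O)c2cc(Oc3ccc(C(=O)N(C)C)cc3)c3cn(C)nc3c2)cn1` gives 14.6 10^-6 cm/s

These values come from an ADME assay on MDCKII-LE cells (Canis lupus familiaris) for permeability (on this read-out higher numbers stand for higher permeability and lower numbers for lower permeability), and all lie within the usual scatter of one another. Compound 3, at 14.6 10^-6 cm/s in this measure, therefore stands level with compound 1 and compound 2.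

Compound 4 `Cc1cnc(NC(=O)c2cc(Oc3ccc(S(=O)(=O)N(C)C)cc3)c3cn(C)nc3c2)cn1` differs from compound 3 in one place: dimethylsulfamoyl in place of dimethylcarbamoyl on an aromatic carbon, para to a large group (dimethylsulfamoyl in place of dimethylcarbamoyl on an aromatic carbon). For the measured compounds named here, no measured pair shows this change alone, so its size cannot be read from the data. Starting from compound 3 at 14.6 10^-6 cm/s as the closest relative, no step beyond the scatter is expected in this assay in either direction. The expected step, a 1.0-fold higher number from compound 3 to compound 4 (0.01 log units; within the scatter) as estimated, stays small. Compound 4 is expected at 15 10^-6 cm/s within an estimated range from 8 10^-6 cm/s to 26 10^-6 cm/s in this measure.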

Compound 4, apparent permeability in the MDCKII-LE assay: 13.6 10^-6 cm/s
Compound 4: the middle estimate sits 1.1-fold (0.04 log units) above what was measured; the range from low to high includes it.
By their numbers in the MDCKII-LE assay, from the lowest: compounds 4, 3, 2 and 1 (each within the scatter of the next).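

For the compounds shown here, in the MDCKII-LE assay, dimethylsulfamoyl in place of dimethylcarbamoyl on this aromatic carbon gives a 1.1-fold lower number from compound 3 to compound 4 (0.03 log units; within the scatter), so this first single-change pair shows no step in permeability beyond the scatter. In a physicochemical assay for solubility, measured as kinetic solubility (on this read-out lower numbers stand for lower solubility and higher numbers for higher solubility), compound 3 gives 351000 nM and compound 4 gives 134000 nM. The same change does register in the physicochemical assay, where it separates the two compounds clearly: the measured solubility of compound 3, 351000 nM, and of compound 4, 134000 nM, a 2.6-fold lower number (0.42 log units; beyond the scatter)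

On these data alone, how a nitrile or a carboxylic acid on this carbon would read in either measure remains open. Also open, as far as these compounds go, is whether this change would behave alike on the cores of compound 1 and compound 2.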